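Trifluoromethoxy for fluoro on the phenoxy ring of compound 3

The compounds below may be only part of what the source reports. "The series", "measured", "known", "first", "only" and "open" are said of these compounds alone.

Of the compounds shown here, three have been measured in a functional assay on SGC-7901 cells (Homo sapiens) for antiproliferative activity, read by MTT assay, with a stated time of 72 h; on this read-out higher numbers stand for weaker inhibition and lower numbers for stronger inhibition. Compound 1 `Cc1nn(C)c(Oc2ccc(F)cc2)c1/C=N\OCc1c(Cl)c(-c2ccc(F)cc2)nn1C` gives 7080 nM. Compound 2 `Cc1ccc(Oc2c(/C=N\OCc3c(Cl)c(-c4ccc(F)cc4)nn3C)c(C)nn2C)cc1` gives 4620 nM. Compound 3 `Cc1nn(C)c(Oc2ccc(F)cc2)c1/C=N\OCc1c(Cl)c(-c2ccc(Cl)cc2)nn1C` gives 4430 nM, and the three numbers lie together within the scatter of one another, so no order among them can be read.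

Two single-point steps are available. The exchange of fluoro for methyl on the phenoxy ring gave a 1.5-fold lower number from compound 1 to compound 2 (0.19 log units; within the scatter), and the exchange of fluoro for chloro on the other aryl ring gave a 1.6-fold lower number from compound 1 to compound 3 (0.20 log units; within the scatter). Neither moved the read-out beyond the scatter.

Compound 4 `Cc1nn(C)c(Oc2ccc(OC(F)(F)F)cc2)c1/C=N\OCc1c(Cl)c(-c2ccc(Cl)cc2)nn1C` is the next step from compound 3: trifluoromethoxy in place of fluoro on an aromatic carbon. This touches the same aromatic carbon as the fluoro-to-methyl step of compound 1 to compound 2, which was within the scatter, so a step of the same order is expected, and the chloro step from compound 1 to compound 3 on the other ring gives no hint of a larger effect.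

The expected outcome for compound 4 in this assay is therefore a number close to that of compound 3, with the step of a 1.1-fold lower number from compound 3 to compound 4 (0.02 log units; within the scatter) lying within the scatter. The estimate for compound 4 is 4200 nM, with a range from 1800 nM to 9500 nM.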

Compound 4, half-maximal inhibitory concentration: 3220 nM
Compound 4: middle estimate off by 1.3-fold (0.12 log units), on the high side; measured number inside the range.
By their numbers in this assay, from the lowest: compounds 4, 3, 2 and 1 (each within the scatter of the next, the first and the last beyond it).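

On the phenoxy ring, the carbon para to a large group now carries a substituent well beyond a single atom: trifluoromethoxy brings five heavy atoms and a hydrogen-bond acceptor where fluoro brings one heavy atom and none, and in this assay this exchange gives a 1.4-fold lower number from compound 3 to compound 4 (0.14 log units; within the scatter) in the setting of the chloro-substituted aryl ring. Together with the methyl exchange, which was made with the fluoro-substituted aryl ring, this means that three groups at this carbon have been compared with fluoro or through it without any step leaving the scatter, so the read-out has shown no sensitivity to the size of the group here across these compounds. Nothing at hand bears on why this exchange stays within the scatter.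

From the compounds shown here alone, it remains open whether a group of another kind on this carbon, such as an amine, a carboxylic acid or a longer alkoxy chain, would move the number beyond the scatter. Also open, going by these compounds, is whether trifluoromethoxy behaves in the same way when the other aryl ring carries fluoro instead of chloro.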